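Benzylthio for thioamide on two diarylamino cores

This account rests on a few compounds, and the source may have more. Where it says the series, first, only, none or still open, it means among the compounds named here.

Compound 1 `Cc1ccc(NC2=C/C(=N/NC(N)=S)C(=O)N=C2Nc2ccc(C)cc2)cc1` carries a group of 4 heavy atoms on a double-bonded nitrogen of its core. In a functional assay on Bel-7402 cells (Homo sapiens) for antiproliferative activity, read by MTT assay, with a stated time of 72 h (a lower number here means a stronger inhibitor, a higher number a weaker inhibitor), compound 1 gives 4330 nM. Compound 3 `Cc1ccc(NC2=C/C(=N/N=C(\N)SCc3ccccc3)C(=O)N=C2Nc2ccc(C)cc2)cc1` differs from compound 1 by a group of 11 heavy atoms (8 carbon, 2 nitrogen, 1 sulfur; one six-membered aromatic ring of carbon only) in place of a group of 4 heavy atoms (1 carbon, 2 nitrogen, 1 sulfur; no ring), on a double-bonded nitrogen, and in this assay compound 3 gives 7680 nM. The measured step is a 1.8-fold higher number from compound 1 to compound 3 (0.25 log units; within the scatter). Compound 2 `NC(=S)N/N=C1/C=C(Nc2cccc(Cl)c2)C(Nc2cccc(Cl)c2)=NC1=O` keeps the same group of 4 heavy atoms but sits on a different core; the difference between the two cores is not broken down here. In this assay compound 2 gives 2190 nM, which lies within the scatter of compound 1 and beyond the scatter from compound 3.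

Compound 4 `N/C(=N\N=C1\C=C(Nc2cccc(Cl)c2)C(Nc2cccc(Cl)c2)=NC1=O)SCc1ccccc1` is not yet measured. It differs from compound 2 by a group of 11 heavy atoms (8 carbon, 2 nitrogen, 1 sulfur; one six-membered aromatic ring of carbon only) in place of a group of 4 heavy atoms (1 carbon, 2 nitrogen, 1 sulfur; no ring), on a double-bonded nitrogen, the same change at the same place as in the measured pair; the change occurs twice among these compounds and has one measured instance. The step expected from it is a 1.8-fold higher number from compound 2 to compound 4 (0.25 log units; within the scatter), set beside a 1.8-fold higher number from compound 1 to compound 3 (0.25 log units; within the scatter), which is the only observation available, with no other comparison across the two cores. Compound 4 is therefore expected to give 3900 nM in this assay, with the range 1800 nM to 8500 nM kept wide, since carrying one step from one core to another rests on a single measurement.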

Compound 4, half-maximal inhibitory concentration: 7160 nM
Beside the measured number, compound 4's estimate is 1.8-fold (0.26 log units) below it; the measured number falls inside the stated range.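

In this assay, putting the group of 11 heavy atoms in place of the group of 4 heavy atoms on a double-bonded nitrogen gives a 3.3-fold higher number from compound 2 to compound 4 (0.51 log units; beyond the scatter). The two steps for this change cannot be told apart, so within these two pairs the change carries from one core to the other without a measurable difference in its size: the same change on two cores in this assay, a 1.8-fold higher number (0.25 log units; within the scatter) from compound 1 to compound 3 and a 3.3-fold higher number (0.51 log units; beyond the scatter) from compound 2 to compound 4, 1.8-fold (0.27 log units) apart, within the scatter of two such steps. Within the data shown here, this does not fix a common size for the step, since only the step on the core of compound 2 lies beyond the scatter, and two pairs cannot predict the step on a third core or explain why the numbers come out as they do.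

The compounds shown leave open whether the step depends on the benzyl part of the entering group, which a methylthio group, a longer chain on the sulfur or an amine in its place would test. They also leave open whether a substituent such as a carboxylic acid on the benzyl ring would alter the step, and whether the step seen in this assay holds in other cell lines.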